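This account rests on a few compounds, and the source may have more. Where it says the series, first, only, none or still open, it means among the compounds named here.

Working notes on the hydroxamic acid series.

For the measured compounds named here, compound 1 `CCCCCN(Cc1ccc(C(=O)NO)cc1)c1ncc(-c2ccc(C)cc2)s1` gives 7020 nM in a functional assay on HepG2 cells (Homo sapiens) for antiproliferative activity, read by MTT assay, with a stated time of 48 h (on this read-out lower numbers stand for stronger inhibition of growth and higher numbers for weaker inhibition of growth), which is the lowest of the two numbers so far. Compound 2 `Cc1ccc(-c2cnc(N(Cc3ccccc3)Cc3ccc(C(=O)NO)cc3)s2)cc1` gives 34000 nM in this assay. Going by the values given here, the one measured step, a 4.8-fold higher number from compound 1 to compound 2 (0.69 log units; beyond the scatter), swaps the butyl of the pentyl chain for a phenyl on the carbon bound to the ring nitrogen.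

Compound 3 `CCCCN(Cc1ccc(C(=O)NO)cc1)c1ncc(-c2ccc(C)cc2)s1` differs from compound 1 by hydrogen in place of methyl on a saturated chain carbon, four bonds along the chain from a nitrogen on an aromatic ring. Among the compounds with values here, no measured pair shows this kind of shortening of the chain; the step from compound 1 to compound 2 concerns a different change at a different carbon and gives no direct guide. Removing one carbon from the end of the chain is a small change, so the expected step in this assay is none beyond the scatter, in either direction. Compound 3 is therefore estimated at 7500 nM, with a range of 3500 nM to 16000 nM, a step of a 1.1-fold higher number from compound 1 to compound 3 (0.03 log units; within the scatter).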

Compound 3, concentration for 50% growth inhibition: 4300 nM
Compound 3: the middle estimate sits 1.7-fold (0.24 log units) above what was measured, within the range that was stated.
By their numbers in this assay, from the lowest: compounds 3 and 1 (each within the scatter of the next); then compound 2.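

In this assay, hydrogen in place of methyl on the saturated chain carbon, four bonds along the chain from a nitrogen on an aromatic ring, gives a 1.6-fold lower number from compound 1 to compound 3 (0.21 log units; within the scatter) and so leaves the read-out unchanged within the scatter: at this position, the end methyl of the pentyl chain can be lost without a measurable effect. The shorter chain also gives a second comparison with the phenyl compound, a 7.9-fold lower number from compound 2 to compound 3 (0.90 log units; beyond the scatter) with propyl in place of phenyl on the saturated chain carbon bound to a nitrogen on an aromatic ring, and this step, like the first one to compound 2, lies beyond the scatter. Nothing at hand gives a reason for either step.

As far as these compounds go, whether a still shorter chain such as propyl or ethyl, or a longer chain such as hexyl, keeps this level remains open. So does the effect of an amine or a carboxylic acid at the chain end.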